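Formamide in place of the aminocyclopropyl group

The compounds below may be only part of what the source reports. "The series", "measured", "known", "first", "only" and "open" are said of these compounds alone.

Compound 2 `Cn1nc2c(=O)n(CC3(O)CCN(Cc4ccc(-c5ccco5)cc4Cl)CC3)cnc2c1-c1ccc(C2(N)CC2)cc1` gives 66.1 nM in an assay on isolated protein for inhibition of ubiquitin carboxyl-terminal hydrolase 7 (Homo sapiens), with stated times of 30 min and 2 h (on this read-out higher numbers stand for weaker inhibition and lower numbers for stronger inhibition), the lower of the two numbers measured; compound 1 `Cn1nc2c(=O)n(CC3(O)CCN(Cc4ccc(-c5ccco5)cc4Cl)CC3)cnc2c1-c1ccc(CNC(=O)C(F)(F)F)cc1` gives 2060 nM in this assay, and the step of a 31-fold lower number from compound 1 to compound 2 (1.49 log units; beyond the scatter) is large. Compound 3 `Cn1nc2c(=O)n(CC3(O)CCN(Cc4ccc(-c5ccco5)cc4Cl)CC3)cnc2c1-c1ccc(CNC=O)cc1` differs from compound 2 by (formylamino)methyl in place of 1-aminocyclopropyl on an aromatic carbon. Among the compounds with values here, the one measured step that bears on this change is the one from compound 1 to compound 2, in which an acylated aminomethyl group gave way to the 1-aminocyclopropyl group with a large fall in the number; the change to compound 3 reverses that kind of exchange, so a large rise is expected, though the formyl group is not the trifluoroacetyl group of compound 1 and the size is uncertain. The step of a 12-fold higher number from compound 2 to compound 3 (1.08 log units; beyond the scatter) is therefore the expectation, beyond the scatter. Compound 3 is estimated at 800 nM, within 250 nM to 2500 nM.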

Compound 3, half-maximal inhibitory concentration: 20.9 nM
For compound 3 the middle estimate is 38-fold (1.58 log units) above the measured one, outside the stated range (below it).
By their numbers in this assay, from the lowest: compound 3; then compound 2; then compound 1.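

In this assay, the step of a 3.2-fold lower number from compound 2 to compound 3 (0.50 log units; beyond the scatter) shows that the 1-aminocyclopropyl group is not needed for a low number at this place on the aromatic ring, since an acylated aminomethyl group can go lower. The step of a 99-fold lower number from compound 1 to compound 3 (1.99 log units; beyond the scatter), with hydrogen in place of trifluoromethyl on the carbonyl carbon, shows that the high number of compound 1 cannot be read as belonging to acylated aminomethyl groups in general. No measurement at hand accounts for the size of either step.

The compounds shown leave open what a methyl group on that carbonyl carbon, as in an acetamide, would give in this series. They also leave open how the plain aminomethyl group, without any acyl group, would compare with compound 3.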